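Vinyl to cyclopropyl on the aryl ether oxygen

A few compounds are considered here, and "the series" means these few. Any claim that something is new, unique, unknown or untested is made for them only; others in the source may bear on it.

Compound 2 `C=COc1ccccc1OC(C)C1=NCCN1` stands lowest of the three numbers in an assay on CHO cells with Alpha-2C adrenergic receptor (Homo sapiens) as the target (a higher number here means a larger maximal response, a lower number a smaller maximal response), giving 0.48; compound 1 `CC(Oc1ccccc1C=O)C1=NCCN1` gives 0.6 and compound 3 `Cc1cccc(C)c1OC(C)C1=NCCN1` gives 0.82. Compound 4 `CC(Oc1ccccc1OC1CC1)C1=NCCN1` differs from compound 2 by cyclopropyl in place of vinyl on an oxygen on an aromatic ring. Going by the values given here, the one measured step that touches this oxygen substituent is a number 0.12 lower from compound 1 to compound 2 (beyond the scatter), so a change at this site has moved the number by a modest amount. Among the compounds with values here, no measured pair exchanges vinyl for cyclopropyl, so the direction is open; a step of similar modest size, a number 0.070 higher from compound 2 to compound 4 (within the scatter), is expected, with no firm sign. Compound 4 is therefore estimated at 0.55, in the range 0.4 to 0.72.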

Compound 4, intrinsic activity: the largest response reached, as a fraction of the reference agonist's: 0.7
The estimate for compound 4 lay 0.15 below the measured number; measured number inside the range.
By their numbers in this assay, from the lowest: compound 2; then compounds 1 and 4 (each within the scatter of the next); then compound 3.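

In this assay, the group on the oxygen on an aromatic ring can raise the maximal response as well as lower it: cyclopropyl in place of vinyl gives a number 0.22 higher from compound 2 to compound 4 (beyond the scatter) at this site. Cyclopropyloxy in place of formyl gives a number 0.10 higher from compound 1 to compound 4 (within the scatter) so, unlike vinyloxy, it stays level with formyl. No measurement here accounts for the gain. From the compounds shown here alone, whether the ring itself matters or only the loss of the vinyl double bond stays open. How an ethyl group, a longer chain or an amine on this oxygen would fare is also unknown.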